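A few compounds are considered here, and "the series" means these few. Any claim that something is new, unique, unknown or untested is made for them only; others in the source may bear on it.

Compound 1 `COc1ccc(-n2c(SCC(=O)c3ccc(OC)c(O)c3)nnc2-c2cc(OC)c(OC)c(OC)c2)cc1` was tested in a functional assay on HepG2 cells (Homo sapiens) for inhibition, read by MTT assay, with a stated time of 48 h; a higher number here means a weaker inhibitor, a lower number a stronger inhibitor. In this assay compound 1 gives > 60000 nM, which is a limit of the assay and not a number. Compound 2 `COc1ccc(-n2c(SCC(=O)c3ccc4ccccc4c3)nnc2-c2cc(OC)c(OC)c(OC)c2)cc1` carries, on the shared core, (naphthalen-2-yl in place of 3-hydroxy-4-methoxyphenyl on a carbonyl carbon). In this assay compound 2 gives > 60000 nM, again a limit. The step that the two limits leave unreadable from compound 1 to compound 2 therefore cannot be sized. Compound 3 `COc1ccc(C(=O)CSc2nnc(-c3cc(OC)c(OC)c(OC)c3)n2-c2ccc(N(C)C)cc2)cc1O` differs from compound 1 in its core by dimethylamino in place of methoxy on an aromatic carbon. In this assay compound 3 gives > 100000 nM, also a limit. The step that the two limits leave unreadable from compound 1 to compound 3 is likewise unreadable. Two of the three values sit at the limit of > 60000 nM in this assay, at which 2 of the 3 values shown sit, and the remaining one sits at the limit of > 100000 nM in this assay, at which 1 of the 3 values shown sits. Compound 4 `COc1cc(-c2nnc(SCC(=O)c3ccc4ccccc4c3)n2-c2ccc(N(C)C)cc2)cc(OC)c1OC` has not yet been measured; it differs from compound 3 by naphthalen-2-yl in place of 3-hydroxy-4-methoxyphenyl on a carbonyl carbon, the same change as between compound 1 and compound 2, at the same place. The step of a number no higher from compound 3 to compound 4 (the limit leaves the size open) is expected to stay unreadable. That expectation rests on compound 3, which gives > 100000 nM, a limit. Compound 4 is therefore expected to give 100000 nM, with a range from 30000 nM to 300000 nM.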

Compound 4, half-maximal inhibitory concentration: > 60000 nM
Compound 4: no number, only a limit; the forecaster's own chance of this, stated with the estimate: 85%; the middle value lies beyond the limit too.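

In this assay compound 4 gives > 60000 nM, which is a limit of the assay and not a number. The steps to compound 4 from compound 3 and from compound 2 therefore cannot be read. The compounds shown leave open whether either change, naphthalen-2-yl for 3-hydroxy-4-methoxyphenyl or dimethylamino for methoxy, alters inhibition at all.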